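The source may report more compounds than this note shows. Statements on the series, on what has been measured and on what is new or still open speak of the compounds shown alone.

Measured so far:
compound 1, `COc1cc(-c2cc(/C=C/C(=O)c3ccc(N)cc3)[nH]n2)cc(OC)c1OC`: 76%
compound 2, `COc1ccc(C(=O)/C=C/c2cc(-c3cc(OC)c(OC)c(OC)c3)n[nH]2)cc1`: 81%

Both compounds were tested in a functional assay on U-251 cells (Homo sapiens) for cytotoxicity, read by sulforhodamine B assay, with a stated time of 48 h, tested at 1 uM; on this read-out higher numbers stand for a weaker effect at the one concentration tested and lower numbers for a stronger effect. In this assay compound 1 gives 76%, and compound 2 gives 81%. Of the two numbers compound 2 gives the one nearer the top, but the step of a number 5 percentage points higher from compound 1 to compound 2 (within the scatter) is within the scatter, so on this read-out the two compounds cannot be told apart. Compound 3, `COc1cc(-c2cc(/C=C/C(=O)c3ccc(F)c(F)c3)[nH]n2)cc(OC)c1OC`, has not yet been measured in this assay. It differs from compound 2 in one place: 3,4-difluorophenyl in place of 4-methoxyphenyl on a carbonyl carbon. Going by the values given here, the only measured step, a number 5 percentage points higher from compound 1 to compound 2 (within the scatter), concerns a group on the same six-membered aromatic ring of carbon only, and it stayed within the scatter; there is no measured step in which a 3,4-difluorophenyl enters, so the new group has no precedent here. On that basis the step of a number 3 percentage points lower from compound 2 to compound 3 (within the scatter) is expected to stay within the scatter of repeated measurements, with no firm direction. Compound 3 is therefore estimated to give 78% in this assay, with a range from 60% to 95%.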

Compound 3, a percentage reported as activity, at one concentration (the size of the read-out at that concentration, not a potency): 87%
Compound 3: the middle estimate sits 9 percentage points below what was measured; the range from low to high includes it.
By their numbers in this assay, from the lowest: compounds 1, 2 and 3 (each within the scatter of the next, the first and the last beyond it).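

On the ring held by the carbonyl carbon, 3,4-difluorophenyl in place of 4-methoxyphenyl in this assay gives a number 6 percentage points higher from compound 2 to compound 3 (within the scatter) and so cannot be told apart from no change, even though the group that enters has fluorine atoms and no hydrogen-bond acceptor. Set against the 4-aminophenyl compound, the same group gives a number 11 percentage points higher from compound 1 to compound 3 (beyond the scatter) in this assay and this is the first step at this position to pass the scatter, so compound 3 has a modestly weaker effect than compound 1 at the one concentration tested, while compound 2 cannot be separated from either of them. Nothing shown here speaks to what lies behind these numbers.

As far as these compounds go, it remains open whether a single fluorine, a chlorine or a hydroxyl on this ring, or a saturated ring such as cyclohexyl on the carbonyl carbon, would stay in the same range as these three compounds. From the compounds shown here alone, all three also share the rest of the core, so what a carboxylic acid or a longer chain elsewhere on it would do remains unknown.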